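The source may hold more compounds than are shown below. What is called first, only, known or untested is meant among the compounds shown, and "the series" means these compounds.

Compound 2 `O=C1COC(c2ccc(/C=C/c3ccc(Cl)cc3)cc2)=NN1` stands at the edge of what an assay on cells for inhibition of Amine oxidase [flavin-containing] A (Homo sapiens), read by Amplex Red, with a stated time of 30 min (a lower number here means a stronger inhibitor, a higher number a weaker inhibitor), can report: in it compound 2 gives > 100000 nM, which is a limit of the assay and not a number. Going by the values given here, its one measured neighbour, compound 1 `O=C1COC(c2ccc(/C=C/c3cccc(F)c3)cc2)=NN1`, carries 3-fluorophenyl where compound 2 carries 4-chlorophenyl. In this assay compound 1 gives > 100000 nM, likewise a limit. Among the compounds with values here, the step that the two limits leave unreadable from compound 1 to compound 2 therefore has no readable size, and the only evidence on this site is the limit of > 100000 nM in this assay, at which 2 of the 2 values shown sit. The change now made is 3-methylphenyl in place of 4-chlorophenyl on a double-bonded chain carbon bound to a double-bonded chain carbon, giving compound 3 `Cc1cccc(/C=C/c2ccc(C3=NNC(=O)CO3)cc2)c1`. Within the data shown here, the single measured step at this position is unreadable, so no direction in this assay can be drawn from it. The step expected from this change, a step that the limit leaves unreadable from compound 2 to compound 3, is an estimate resting on two limits alone. Compound 3 is therefore expected to give 150000 nM, with a range from 30000 nM to 1000000 nM, most likely again reported only as a limit.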

Compound 3, half-maximal inhibitory concentration: > 100000 nM
Compound 3: only a limit was reported; the forecaster's own chance of this, stated with the estimate: 85%; the middle value is on the limit's open side.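

In this assay, going by these compounds alone, compound 3 gives > 100000 nM, a limit of the assay and not a number, so no step linking it to compound 1 or compound 2 can be read. The compounds shown leave open whether 3-fluorophenyl, 4-chlorophenyl and 3-methylphenyl differ at all in this assay.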